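A few compounds are considered here, and "the series" means these few. Any claim that something is new, unique, unknown or untested is made for them only; others in the source may bear on it.

Working notes on the series. Compound 1 `COc1ccc(-c2cc(/C=C/C(=O)c3ccc(N)cc3)[nH]n2)cc1` gives in a functional assay on CCRF-CEM cells (Homo sapiens) for inhibition, read by sulforhodamine B assay, with a stated time of 48 h (a higher number here means a weaker inhibitor of growth, a lower number a stronger inhibitor of growth), a value of 1320 nM. Compound 2 `COc1ccc(C(=O)/C=C/c2cc(-c3cc(OC)c(OC)c(OC)c3)n[nH]2)cc1` gives in this assay a value of 1420 nM; the two numbers lie within the scatter of each other, so neither can be set apart. Compound 3 `COc1ccc(-c2cc(/C=C/C(=O)c3ccc(N)cc3)[nH]n2)cc1OC` is not yet measured; it differs from compound 1 by methoxy in place of hydrogen on an aromatic carbon. Among the compounds with values here, no measured pair shows this change, so the expectation rests only on the values of compound 1 and compound 2. The expected step of a 1.1-fold lower number from compound 1 to compound 3 (0.04 log units; within the scatter) is small, none beyond the scatter. Compound 3 is estimated at 1200 nM, with a range of 450 nM to 3200 nM.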

Compound 3, concentration for 50% growth inhibition: 1740 nM
Compound 3: middle estimate off by 1.5-fold (0.16 log units), on the low side, within the range that was stated.
By their numbers in this assay, from the lowest: compounds 1, 2 and 3 (each within the scatter of the next).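

Within the data shown here, the step of a 1.3-fold higher number from compound 1 to compound 3 (0.12 log units; within the scatter) in this assay gives the first measured reading of methoxy in place of hydrogen on this aromatic carbon, ortho to a methoxy group and meta to a large group. On the core of compound 1, this position takes the added methoxy with no step beyond the scatter. Nothing measured here bears on a cause for this result. Open, going by these compounds, is whether a hydroxy group, a fluorine atom or a longer ethoxy chain at this place would also stay within the scatter of compound 1.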